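A few compounds are considered here, and "the series" means these few. Any claim that something is new, unique, unknown or untested is made for them only; others in the source may bear on it.

Values in a functional assay on SK-MEL-28 cells (Homo sapiens) for inhibition, read by sulforhodamine B assay, with a stated time of 48 h (on this read-out lower numbers stand for stronger inhibition of growth and higher numbers for weaker inhibition of growth), for the measured members of the series:

compound 1 `Nc1cc(N)c2nc(-c3ccccc3)c(Oc3ccc(Cl)c(Cl)c3)nc2c1` gives 21400 nM
compound 2 `Nc1cc(N)c2nc(-c3ccccc3)c(NCc3ccc(Cl)c(Cl)c3)nc2c1` gives 18600 nM
compound 3 `CCOC(=O)[C@H](CCC(=O)O)NC(=O)c1ccc(Sc2nc3cc(N)cc(N)c3nc2-c2ccccc2)cc1` gives 6760 nM

Compound 2 stands second highest of the three numbers. Its nearest neighbour is compound 1, whose number lies within the scatter of that of compound 2, so no order between the two can be read. The furthest is compound 3, whose number lies beyond the scatter on the lower side, so compound 3 inhibits growth more strongly than compound 2 on this assay. Going by the values given here, no pair of measured compounds differs in a single place, so no measured step is available as a yardstick.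

Compound 4 `COc1ccc(CNc2nc3cc(N)cc(N)c3nc2-c2ccccc2)cc1` is not yet measured. It differs from compound 2 by 4-methoxyphenyl in place of 3,4-dichlorophenyl on a saturated chain carbon bound to a nitrogen on an aromatic ring. Among the compounds with values here, nothing among the measured compounds speaks to a change of this kind at this place. The expectation is for no step beyond the scatter, with a slight lean toward a higher number, so compound 4 is estimated at 26000 nM with a range of 8000 nM to 85000 nM. This estimate corresponds to an expected step of a 1.4-fold higher number from compound 2 to compound 4 (0.15 log units; within the scatter).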

Compound 4, concentration for 50% growth inhibition: 17400 nM
Compound 4: middle estimate off by 1.5-fold (0.17 log units), on the high side; low and high end bracket the measured number.
By their numbers in this assay, from the lowest: compound 3; then compounds 4, 2 and 1 (each within the scatter of the next).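

In this assay, the series now has its first single-place step: 4-methoxyphenyl in place of 3,4-dichlorophenyl gives a 1.1-fold lower number from compound 2 to compound 4 (0.03 log units; within the scatter). At this place, on a saturated chain carbon bound to a nitrogen on an aromatic ring, one substituted phenyl group can therefore replace the other with no readable change in growth inhibition, even though the two groups share no substituent. Nothing at hand accounts for this flat step.

On these data alone, whether an amine or a carboxylic acid in place of the methoxy group, or a longer chain in place of the saturated chain carbon, would produce a step beyond the scatter remains open. Also open, as far as these compounds go, is how the link from the shared core to the aryl group alone bears on growth inhibition.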